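Nitro to fluoro on compound 3: working notes

The source may hold more compounds than are shown below. What is called first, only, known or untested is meant among the compounds shown, and "the series" means these compounds.

Three compounds have numbers in a functional assay on HepG2 cells (Homo sapiens) for cytotoxicity, read by spectrophotometry, with a stated time of 72 h (on this read-out lower numbers stand for stronger inhibition and higher numbers for weaker inhibition), so far. Compound 1 (`COc1ccc(-c2cccc(=O)n2-c2cc(OC)c(OC)c(OC)c2)cc1OCc1ccccc1`) gives 269 nM and compound 2 (`COc1cc(-n2c(-c3cccc(O)c3)cccc2=O)cc(OC)c1OC`) gives 34 nM in this assay. Compound 3 (`COc1cc(-c2cccc(=O)n2-c2ccc([N+](=O)[O-])cc2)cc(OC)c1OC`) gives 941 nM as the highest number of the three, and its gaps to both others lie beyond the scatter.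

Compound 4 (`COc1cc(-c2cccc(=O)n2-c2ccc(F)cc2)cc(OC)c1OC`) is still unmeasured. It differs from compound 3 by one change, 4-nitrophenyl to 4-fluorophenyl (fluoro in place of nitro on an aromatic carbon), with fluoro in place of nitro on an aromatic carbon. Within the data shown here, no two measured compounds differ in one place only, so the data offer no direct precedent for this change. Among the measured compounds shown here, the only guide is that compound 3 at 941 nM stands at the top of a small range, which leaves more room for a fall than a rise.

A small step to a lower number is expected, estimated as a 1.9-fold lower number from compound 3 to compound 4 (0.27 log units; within the scatter) and lying at the edge of the scatter. The expected value for compound 4 is 500 nM, with an estimated range from 130 nM to 1800 nM.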

Compound 4, half-maximal inhibitory concentration: > 100000 nM
Compound 4: no number, only a limit; the forecaster's own chance of this, stated with the estimate: 3%; middle value at least 200-fold (2.30 log units) from the limit.
By their numbers in this assay, from the lowest: compound 2; then compound 1; then compound 3. At a limit, above all of these: compound 4.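

In this assay compound 4 gives > 100000 nM, which is a limit of the assay and not a number. Fluoro in place of nitro on this aromatic carbon, para to a large group, is the only single change that can be read in the series so far, and it gives an at least 100-fold higher number from compound 3 to compound 4 (2.02 log units; beyond the scatter). The position is thus far from indifferent to what it carries: nitro leaves a measurable number and fluoro does not, though the size of the step is bounded on one side only: the limit of > 100000 nM in this assay, at which 1 of the 4 values shown sits.

This one pair cannot tell whether the loss comes from removing nitro or from introducing fluoro. Going by these compounds, how an amine, a nitrile or a carboxylic acid would read at this place stays open, as does the effect of the same change on the other compounds.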